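Swapping Methyl for Chloro: Expected Cytotoxicity of Compound 4

A few compounds are considered here, and "the series" means these few. Any claim that something is new, unique, unknown or untested is made for them only; others in the source may bear on it.

Of the compounds shown here, three that share one core have been tested in an ADME assay on NIH3T3 cells (Mus musculus) for cytotoxicity, read by XTT assay, with a stated time of 24 h; on this read-out lower numbers stand for stronger inhibition and higher numbers for weaker inhibition. Compound 1 `Cc1ccc(C2=NN(c3nc(-c4ccc(Cl)cc4)cs3)C(c3ccc(F)cc3)C2)s1` gives only a limit, > 500 ug/mL. Compound 2 `Cc1ccc(-c2csc(N3N=C(c4ccc(C)s4)CC3c3ccc(F)cc3)n2)cc1` likewise gives only a limit, > 500 ug/mL. Within the data shown here, compound 3 `COc1ccc(-c2csc(N3N=C(c4ccc(C)s4)CC3c3ccc(F)cc3)n2)cc1` is the one compound with a measured number, 147 ug/mL. The step of an at least 3.4-fold lower number from compound 1 to compound 3 (0.53 log units; beyond the scatter) and the step of an at least 3.4-fold lower number from compound 2 to compound 3 (0.53 log units; beyond the scatter) both run toward this lower number, whereas a step that the two limits leave unreadable from compound 1 to compound 2 cannot be read because both of its values sit at the limit of > 500 ug/mL in this assay, at which 2 of the 3 values shown sit.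

Compound 4 `COc1ccc(-c2csc(N3N=C(c4ccc(Cl)s4)CC3c3ccc(F)cc3)n2)cc1` differs from compound 3 by chloro in place of methyl on an aromatic carbon. Among the measured compounds shown here, the only measured step that trades methyl against chloro is a step that the two limits leave unreadable from compound 1 to compound 2, and it is unreadable; the two readable steps concern methoxy and do not touch this change. With nothing readable pointing either way, the step expected for compound 4 is a 1.0-fold higher number from compound 3 to compound 4 (0.01 log units; within the scatter), nothing beyond the scatter. The estimate for compound 4 in this assay is therefore 150 ug/mL, between 60 ug/mL and 400 ug/mL.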

Compound 4, half-maximal inhibitory concentration: 103 ug/mL
Compound 4: the middle estimate sits 1.5-fold (0.16 log units) above what was measured, and the stated range covers the measured number.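

Exchanging 5-methylthiophen-2-yl for 5-chlorothiophen-2-yl gives the first readable trade of methyl and chloro in this assay: a 1.4-fold lower number from compound 3 to compound 4 (0.15 log units; within the scatter), a step that stays within the scatter. The only earlier trade of these two groups, made at a different place on the molecule, cannot be read, because both of its values sit at a limit: the limit of > 500 ug/mL in this assay, at which 2 of the 4 values shown sit. In this one pair, with the methoxy group present, either group can stand at this carbon of the sulfur-bearing ring with no change beyond the scatter.

Among these compounds, whether the same trade would stay this small without the methoxy group remains open, as only one readable pair carries it. Also open, on these data alone, is what an amine, a carboxylic acid or a longer chain such as propyl at this carbon would do in this assay.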